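The compounds below may be only part of what the source reports. "The series", "measured", "known", "first", "only" and "open" are said of these compounds alone.

In an assay on isolated protein for inhibition of Gonadotropin-releasing hormone receptor (Rattus norvegicus) (on this read-out higher numbers stand for weaker inhibition and lower numbers for stronger inhibition), compound 1 `Cc1cc(C)cc(-c2c(O)nc3cc(Cl)c([N+](=O)[O-])cc3c2OCC[C@@H]2Cc3ccccc3CN2)c1` gives 70 nM, and compound 2 `Cc1cc(C)cc(-c2c(O)nc3cc(Cl)c([N+](=O)[O-])cc3c2OCCC2NCCc3ccccc32)c1` gives 750 nM. Within the data shown here, the one measured step, an 11-fold higher number from compound 1 to compound 2 (1.03 log units; beyond the scatter), moves the attachment point of the same bicyclic amine on the chain. Among the two numbers in this assay, compound 2 carries the higher one. Compound 3 `Cc1cc(C)cc(-c2c(O)nc3cc(Cl)c([N+](=O)[O-])cc3c2OCC[C@@H]2CCC[C@H](C)N2)c1` differs from compound 2 by 6-methylpiperidin-2-yl in place of 1,2,3,4-tetrahydroisoquinolin-1-yl on a saturated chain carbon, two bonds along the chain from an oxygen on an aromatic ring: the fused aromatic ring is gone and a smaller, methyl-bearing saturated amine ring takes its place, so the measured step bears on it only loosely, as a sign that this part of the molecule can shift this assay strongly. With the fused ring removed and the amine kept close to the chain, the expectation is a marked fall of a 30-fold lower number from compound 2 to compound 3 (1.48 log units; beyond the scatter) in this assay. Compound 3 is therefore estimated at 25 nM, within a range from 5 nM to 150 nM.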

Compound 3, half-maximal inhibitory concentration: 15 nM
For compound 3 the middle estimate is 1.7-fold (0.22 log units) above the measured one; the measured number falls inside the stated range.
By their numbers in this assay, from the lowest: compound 3; then compound 1; then compound 2.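

Removing the six-membered aromatic ring from the amine group does not cost binding at this position in this assay. The smaller 6-methylpiperidin-2-yl gives a 50-fold lower number from compound 2 to compound 3 (1.70 log units; beyond the scatter), so an aromatic ring in this group is not required for a low number. The change is more than a recovery from the weak compound 2, as the same group also gives a 4.7-fold lower number from compound 1 to compound 3 (0.67 log units; beyond the scatter), making compound 3 the strongest inhibitor of the three. No supporting data are available to explain these shifts.

The role of the methyl remains open: the compounds shown cannot separate its contribution from that of losing the aromatic ring. Plain piperidin-2-yl or 6-ethylpiperidin-2-yl at this position would test this directly, and the opposite arrangement of the two defined stereocentres is also unexplored here.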